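Moving the Acid Around the Outer Ring

The source may hold more compounds than are shown below. What is called first, only, known or untested is meant among the compounds shown, and "the series" means these compounds.

Compound 1 `O=C1c2ccc(OCc3cccc(-c4ccc(Cl)cc4F)c3)cc2CN1C1CCCC1` in an assay on HEK293 cells for positive allosteric modulation of metabotropic glutamate receptor 2 (Rattus norvegicus), read by thallium flux; on this read-out lower numbers stand for an effect already at smaller amounts and higher numbers for an effect only at larger amounts of compound: > 5000 nM, a limit of the assay, not a number.
Compound 2 `COc1ccc(C(=O)O)cc1-c1cccc(COc2ccc3c(c2)CN(C2CCCC2)C3=O)c1`: 80 nM.
Compound 3 `O=C(O)c1ccc(Cl)c(-c2cccc(COc3ccc4c(c3)CN(C3CCCC3)C4=O)c2)c1`: 90 nM.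

Compound 3 stands at the highest of the two numbers measured, yet compound 2 sits so close that the step of a 1.1-fold higher number from compound 2 to compound 3 (0.05 log units; within the scatter) lies within the scatter. Compound 1 gives only a limit (the limit of > 5000 nM in this assay, at which 1 of the 3 values shown sits). The change to compound 4 `COc1ccc(-c2cccc(COc3ccc4c(c3)CN(C3CCCC3)C4=O)c2)cc1C(=O)O` is 3-carboxy-4-methoxyphenyl in place of 5-carboxy-2-chlorophenyl on an aromatic carbon. Among the measured compounds shown here, two measured steps bear on it. The step of an at least 55-fold lower number from compound 1 to compound 3 (1.74 log units; beyond the scatter) shows that entry of a carboxy-bearing ring lowers the number a great deal; the step of a 1.1-fold higher number from compound 2 to compound 3 (0.05 log units; within the scatter) shows that exchanging chloro for methoxy changes little. Compound 4 keeps a carboxy group and a methoxy group but places both differently, and compound 1 shows the outer ring matters. A small rise in number beyond the scatter is therefore expected for compound 4, as a 2.0-fold higher number from compound 3 to compound 4 (0.30 log units; within the scatter). The estimate for compound 4 is 180 nM, ranging from 50 nM to 900 nM.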

Compound 4, half-maximal effective concentration: 170 nM
Beside the measured number, compound 4's estimate is 1.1-fold (0.02 log units) above it; measured number inside the range.
By their numbers in this assay, from the lowest: compounds 2, 3 and 4 (each within the scatter of the next, the first and the last beyond it). At a limit, above all of these: compound 1.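

Placement alone can be read here, since the same two groups sit on the outer ring in compound 2 and compound 4, and the step is small but real: a 2.1-fold higher number from compound 2 to compound 4 (0.33 log units; beyond the scatter). Against the chloro-bearing ring the change stays within the usual scatter, a 1.9-fold higher number from compound 3 to compound 4 (0.28 log units; within the scatter), while the gain over the ring without a carboxy group holds for this third arrangement too, an at least 29-fold lower number from compound 1 to compound 4 (1.46 log units; beyond the scatter). That last step is only a bound, as compound 1 gives a limit and not a number: the limit of > 5000 nM in this assay, at which 1 of the 4 values shown sits.

Going by these compounds, what stays open is whether the carboxy group is needed as such, or whether a tetrazole or a sulfonamide on the same ring would read alike in this assay. Also open, on these data alone, is how a plain 3-carboxyphenyl ring, with neither methoxy nor chloro, would compare.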